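Toll-like receptor 2 agonists: an aromatic amide substituent

The source may report more compounds than this note shows. Statements on the series, on what has been measured and on what is new or still open speak of the compounds shown alone.

Three compounds share one core and differ only in the group on the amide-type nitrogen. Compound 1 `CCCCCCCCCCCC(=O)OC[C@H](CSC[C@@H](N)C(=O)NC(C)(C)CO)OC(=O)CCCCCCCCCCC` gives 15500 nM in an assay on HEK293 cells for agonist activity at Toll-like receptor 2 (Homo sapiens); on this read-out lower numbers stand for an effect already at smaller amounts and higher numbers for an effect only at larger amounts of compound. Compound 2 `CCCCCCCCCCCC(=O)OC[C@H](CSC[C@@H](N)C(=O)N[C@@H](C)CO)OC(=O)CCCCCCCCCCC` gives 1560 nM, and compound 3 `CCCCCCCCCCCC(=O)OC[C@H](CSC[C@@H](N)C(=O)NCCO)OC(=O)CCCCCCCCCCC` gives 24 nM. Compound 2 thus stands second highest of the three numbers, with compound 1 nearest and compound 3 furthest away.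

For the measured compounds named here, two steps bear on the change now in question. a 9.9-fold lower number from compound 1 to compound 2 (1.00 log units; beyond the scatter), and a 65-fold lower number from compound 2 to compound 3 (1.81 log units; beyond the scatter); the largest step overall is a 650-fold lower number from compound 1 to compound 3 (2.81 log units; beyond the scatter). Each of these is a move to a smaller group on the amide-type nitrogen, and each brought a lower number.

Compound 4 `CCCCCCCCCCCC(=O)OC[C@H](CSC[C@@H](N)C(=O)NC(C)c1ccc(O)cc1)OC(=O)CCCCCCCCCCC` goes the other way. The change from compound 2 is 1-(4-hydroxyphenyl)ethyl in place of 1-(hydroxymethyl)ethyl on an amide-type nitrogen. Going by the values given here, the methyl on the chain carbon bound to the amide-type nitrogen is kept, and a much larger group enters; no measured compound carries an aromatic ring at this position, so the direction rests on the size trend alone. A modestly higher number is therefore expected for compound 4 in this assay, a 2.2-fold higher number from compound 2 to compound 4 (0.35 log units; beyond the scatter), although the wide range reflects the absence of a direct precedent. The estimate for compound 4 is 3500 nM, between 800 nM and 16000 nM.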

Compound 4, half-maximal effective concentration: 2890 nM
Compound 4: the middle estimate sits 1.2-fold (0.08 log units) above what was measured, and the stated range covers the measured number.
By their numbers in this assay, from the lowest: compound 3; then compounds 2 and 4 (each within the scatter of the next); then compound 1.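

In this assay, replacing 1-(hydroxymethyl)ethyl with the larger 1-(4-hydroxyphenyl)ethyl, which brings one six-membered aromatic ring, gives a 1.9-fold higher number from compound 2 to compound 4 (0.27 log units; within the scatter), so compound 2 and compound 4 cannot be told apart, and the added size and ring carry no measurable penalty here. Size alone therefore does not order this position: compound 4 carries the largest group of the four yet goes against the earlier trend of smaller groups giving lower numbers, with a 5.4-fold lower number from compound 1 to compound 4 (0.73 log units; beyond the scatter), although the 2-hydroxyethyl group remains far ahead, with a 120-fold higher number from compound 3 to compound 4 (2.08 log units; beyond the scatter). Nothing measured here explains why the aromatic group is tolerated as well as it is.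

The compounds shown leave open whether an aromatic group can reach the level of compound 3 once the methyl on the chain carbon is gone, as in 2-(4-hydroxyphenyl)ethyl. They also leave open what the ring hydroxyl contributes, which 1-phenylethyl or a 1-(4-aminophenyl)ethyl group would test, and how the two separate mirror-image forms of the 1-(4-hydroxyphenyl)ethyl group compare.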